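Methyl for dimethylamino on the shared core

A few compounds are considered here, and "the series" means these few. Any claim that something is new, unique, unknown or untested is made for them only; others in the source may bear on it.

Measured so far:
compound 1, `Cn1c(=O)c2nc(-c3cccc(F)c3)[nH]c2n(C)c1=O`, 4 nM
compound 2, `CN(C)c1cccc(-c2nc3c(=O)n(C)c(=O)n(C)c3[nH]2)c1`, 80 nM
compound 3, `Cn1c(=O)c2nc(-c3ccccc3[N+](=O)[O-])[nH]c2n(C)c1=O`, 80 nM

In an assay for binding affinity to adenosine receptor A1 (Bos taurus) (a higher number here means a weaker inhibitor, a lower number a stronger inhibitor), compound 2 gives 80 nM. On the numbers shown it is level with compound 3 at the digits given, and the two together give the highest numbers of the three; its furthest neighbour is compound 1, which gives 4 nM. Going by the values given here, the one step so far that touches the same aromatic carbon is a 20-fold higher number from compound 1 to compound 2 (1.30 log units; beyond the scatter).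

Compound 4, `Cc1cccc(-c2nc3c(=O)n(C)c(=O)n(C)c3[nH]2)c1`, has not been measured. It differs from compound 2 as follows: methyl in place of dimethylamino on an aromatic carbon. The change runs back towards a small substituent at the place where compound 1 carries fluoro, so the relevant measured step is the large one from compound 1 to compound 2. The account therefore expects the number to fall again, though not necessarily all the way back to that of compound 1, so the expected step is a 5.3-fold lower number from compound 2 to compound 4 (0.73 log units; beyond the scatter). Compound 4 is estimated at 15 nM, with a range from 4 nM to 60 nM.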

Compound 4, half-maximal inhibitory concentration: 13 nM
For compound 4 the middle estimate is 1.2-fold (0.06 log units) above the measured one, and the stated range covers the measured number.
By their numbers in this assay, from the lowest: compound 1; then compound 4; then compounds 2 and 3 (each within the scatter of the next).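

In this assay methyl in place of dimethylamino on the aromatic carbon gives a 6.2-fold lower number from compound 2 to compound 4 (0.79 log units; beyond the scatter), so most of the rise seen with dimethylamino is lost when a single carbon stands there instead. Methyl does not fully match fluoro, however: the comparison gives a 3.3-fold higher number from compound 1 to compound 4 (0.51 log units; beyond the scatter), which shows that this position also separates two groups of few heavy atoms. Nothing available explains this order of fluoro, methyl and dimethylamino.

The compounds shown compare only these three groups at this carbon, so it stays open how a chlorine, a methoxy group or a primary amine would read there. Going by these compounds alone, they also give no step for a nitro group at this carbon, which leaves that comparison open too.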